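A few compounds are considered here, and "the series" means these few. Any claim that something is new, unique, unknown or untested is made for them only; others in the source may bear on it.

Compound 1 `Cc1cc2cc(NS(=O)(=O)Cc3ccc(C(=O)NO)cc3)ccc2n(C)c1=O` belongs to a set of three compounds tested in a functional assay on HL-60 cells (Homo sapiens) for antiproliferative activity, tested at 100 uM (a lower number here means a weaker effect, a higher number a stronger effect of the compound at the concentration tested), where compound 1 gives 27%. Among the three numbers, compound 1 stands second highest. The nearest is compound 3 `Cc1cc2cc(NS(=O)(=O)Cc3cccc(C(=O)NO)c3)ccc2n(C)c1=O`, which in this assay gives 0%, a lower number, and the gap between the two lies beyond the usual scatter. The furthest is compound 2 `COC(=O)c1ccc(OC)c(S(=O)(=O)Nc2ccc3c(c2)cc(C)c(=O)n3C)c1`, which in this assay gives 66%, the highest of the three, again beyond the scatter from compound 1.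

Compound 4 `COc1cc(C(=O)NO)ccc1CS(=O)(=O)Nc1ccc2c(c1)cc(C)c(=O)n2C` has not yet been measured. It differs from compound 1 in one place: methoxy in place of hydrogen on an aromatic carbon.

Among the compounds with values here, no measured pair in this set shows what such a change does in this assay, so the size of the step is open. The expected step is a number 3 percentage points higher from compound 1 to compound 4 (within the scatter), which means none beyond the scatter in either direction. Compound 4 is therefore estimated to give 30% in this assay, with a range from 10% to 55%.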

Compound 4, a percentage reported as inhibition, at one concentration (the size of the read-out at that concentration, not a potency): 0%
Beside the measured number, compound 4's estimate is 30 percentage points above it, and the stated range ends above it.
By their numbers in this assay, from the lowest: compounds 3 and 4 (each within the scatter of the next); then compound 1; then compound 2.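

Within the data shown here, this is the first single-place comparison in the set. In this assay, methoxy in place of hydrogen on an aromatic carbon, ortho to a large group and meta to the hydroxycarbamoyl group, comes with a number 27 percentage points lower from compound 1 to compound 4 (beyond the scatter), so this position is not indifferent to substitution, at least where methoxy is concerned. The compounds shown offer nothing that accounts for this loss.

Going by these compounds, whether fluorine, a hydroxyl group or an amine on this same carbon would keep the effect of compound 1 remains open, as does whether methoxy on another carbon of the same ring would bring a similar loss. Among these compounds, with only one step available, it is also unclear whether this result reflects methoxy specifically or any group placed there.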